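The compounds below may be only part of what the source reports. "The series", "measured", "known", "first", "only" and "open" are said of these compounds alone.

Measured so far:
Compound 1, `Cc1ccc(C2(CNC(=O)Nc3c(C(C)C)cccc3C(C)C)CCCC2)cc1` — in an assay on microsomes for inhibition of acyl-CoA:cholesterol acyltransferase (Oryctolagus cuniculus) (a higher number here means a weaker inhibitor, a lower number a stronger inhibitor), compound 1 gives 25 nM.
Compound 2, `CC(C)c1cccc(C(C)C)c1NC(=O)NCC1(c2ccc(F)cc2)CCCC1` — in this assay compound 2 gives 23 nM.
Compound 3, `COc1cccc(C2(CNC(=O)Nc3c(C(C)C)cccc3C(C)C)CCCC2)c1` — in this assay compound 3 gives 13 nM.

All three compounds share the same core and differ only in the aromatic group attached to a saturated ring carbon. Compound 3 gives the smallest of the three numbers, but the gaps to the others are small: a 1.9-fold lower number from compound 1 to compound 3 (0.28 log units; within the scatter) and a 1.8-fold lower number from compound 2 to compound 3 (0.25 log units; within the scatter). Going by the values given here, the one step that does not involve compound 3, a 1.1-fold lower number from compound 1 to compound 2 (0.04 log units; within the scatter), is also small.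

Compound 4, `CC(C)c1cccc(C(C)C)c1NC(=O)NCC1(c2ccc(C(F)(F)F)cc2)CCCC1`, makes a change of the same kind: 4-(trifluoromethyl)phenyl in place of 3-methoxyphenyl on a saturated ring carbon. Since every measured exchange of this aromatic group left the number within the scatter, no step beyond the scatter is expected here either, in either direction. The estimated step is a 1.4-fold higher number from compound 3 to compound 4 (0.14 log units; within the scatter). Compound 4 is therefore expected to give about 18 nM in this assay, with a range from 7 nM to 45 nM.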

Compound 4, half-maximal inhibitory concentration: 66 nM
Compound 4: middle estimate off by 3.7-fold (0.56 log units), on the low side; the measured number lies above the stated range.
By their numbers in this assay, from the lowest: compounds 3, 2 and 1 (each within the scatter of the next); then compound 4.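

On the saturated ring carbon, the aromatic group is not freely exchangeable: 4-(trifluoromethyl)phenyl moves the number beyond the scatter in this assay in all three steps: (a 5.1-fold higher number from compound 3 to compound 4 (0.71 log units; beyond the scatter)), (a 2.9-fold higher number from compound 2 to compound 4 (0.46 log units; beyond the scatter)) and (a 2.6-fold higher number from compound 1 to compound 4 (0.42 log units; beyond the scatter)). The last two steps change only the group on the aromatic carbon, so trifluoromethyl separates from both fluoro and methyl, although those two stay within the scatter of each other. Nothing available bears on what lies behind this rise.

The compounds shown leave open whether a chlorine atom, a nitrile or a tert-butyl group on the aromatic carbon would read like fluoro and methyl or like trifluoromethyl. They also leave open how a cyclohexyl ring would read in place of the aromatic group on the saturated ring carbon.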